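The source may report more compounds than this note shows. Statements on the series, on what has been measured and on what is new or still open speak of the compounds shown alone.

Measured so far in an assay on cells for inhibition of cyclic GMP-AMP synthase (Homo sapiens), read by mass spectrometry, with a stated time of 30 min, in the presence of a further agent that is not named here; on this read-out higher numbers stand for weaker inhibition and lower numbers for stronger inhibition: compound 1 `CNC(=O)c1cnn2c(O)cc(-c3ccccc3)nc12` gives 69000 nM; compound 2 `O=C(NCCO)c1cnn2c(O)cc(-c3ccccc3)nc12` gives 19000 nM.

Compound 2 stands as the lower of the two numbers in this assay. For the measured compounds named here, the only step in hand, a 3.6-fold lower number from compound 1 to compound 2 (0.56 log units; beyond the scatter), came from the hydroxymethyl added to the amide substituent. Compound 3 `C[C@@H](CO)NC(=O)c1cnn2c(O)cc(-c3ccccc3)nc12` carries a different change: methyl in place of hydrogen on a saturated chain carbon bound to an amide-type nitrogen and a saturated chain carbon. Going by the values given here, no measured step adds a methyl at this place, so the hydroxymethyl step offers no direct guide, and a shift within the scatter is expected. Compound 3 is therefore estimated at 19000 nM, range 8000 nM to 45000 nM, an expected step of no change at the digits printed from compound 2 to compound 3 (within the scatter).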

Compound 3, half-maximal inhibitory concentration: 8100 nM
Beside the measured number, compound 3's estimate is 2.3-fold (0.37 log units) above it; the measured number falls inside the stated range.
By their numbers in this assay, from the lowest: compound 3; then compound 2; then compound 1.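

In this assay, for the compounds shown here, methyl in place of hydrogen on the saturated chain carbon bound to the amide-type nitrogen gives a 2.3-fold lower number from compound 2 to compound 3 (0.37 log units; beyond the scatter) and shows that this carbon, unchanged between the earlier compounds, also responds to substitution. With 1-(hydroxymethyl)ethyl in place of methyl on the amide-type nitrogen, the two changes together give an 8.5-fold lower number from compound 1 to compound 3 (0.93 log units; beyond the scatter) on the shared core. No available evidence bears on the origin of these steps.

Open: whether the opposite configuration at this carbon gives the same number. As far as these compounds go, also open: what an ethyl group there, or an amine in place of the hydroxyl, would give.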